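The source may hold more compounds than are shown below. What is called first, only, known or untested is meant among the compounds shown, and "the series" means these compounds.

Compound 1 `CC(C)C(c1ccc(-c2ccc3cccc(F)c3c2)[nH]c1=O)N1CCCCS1(=O)=O`: 0.07 h.
Compound 2 `CC(C)C(c1ccc(-c2ccc3cccc(F)c3c2)[nH]c1=O)N1CCN/C1=N\C#N`: 0.327 h.
Compound 3 `CC(C)C(c1ncc[nH]1)c1ccc(-c2ccc3cccc(F)c3c2)[nH]c1=O`: < 0.0667 h, a limit.

Among the measured compounds shown here, in an ADME assay on microsomes from liver (Rattus norvegicus) for metabolic stability (a lower number here means that the compound disappears faster, a higher number that the compound lasts longer), compound 1 stands at the lower of the two numbers given; the only other number lies higher: a 4.7-fold higher number from compound 1 to compound 2 (0.67 log units; beyond the scatter). For compound 3 the reading is a limit of this assay, as recorded in the limit of < 0.0667 h in this assay, at which 1 of the 3 values shown sits. Compound 4 `CC(C)C(c1noc(=O)[nH]1)c1ccc(-c2ccc3cccc(F)c3c2)[nH]c1=O` differs from compound 1 in one place: a group of 6 heavy atoms (2 carbon, 2 nitrogen, 2 oxygen; one five-membered aromatic ring with 3 hetero atoms) in place of a group of 8 heavy atoms (4 carbon, 1 nitrogen, 2 oxygen, 1 sulfur; one six-membered non-aromatic ring with 2 hetero atoms), on a saturated chain carbon bound to an aromatic carbon and a saturated chain carbon. The step that bears on this most also brought in a five-membered aromatic ring at the same place: an at least 1.0-fold lower number from compound 1 to compound 3 (0.02 log units; that floor lies within the scatter). The rise seen with a non-aromatic ring entering is a weaker guide. Compound 4 is therefore expected to show no step beyond the scatter, no change at the digits printed from compound 1 to compound 4 (within the scatter), with an estimated 0.07 h (range 0.03 h to 0.18 h).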

Compound 4, half-life: > 3 h
Compound 4 was reported as a limit (the forecaster's own chance of this, stated with the estimate: 45%); at least 42-fold (1.63 log units) between middle value and limit.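

In this assay, exchanging one five-membered aromatic ring for another on the saturated chain carbon gives an at least 44-fold higher number from compound 3 to compound 4 (1.65 log units; beyond the scatter), so a five-membered aromatic ring as such does not settle the number at this place. The ring in compound 4 also stands clear of both non-aromatic rings, with an at least 42-fold higher number from compound 1 to compound 4 (1.63 log units; beyond the scatter) and an at least 9.1-fold higher number from compound 2 to compound 4 (0.96 log units; beyond the scatter). The reading of compound 4 is a limit of the assay, so the full size of these steps stays open: the limit of > 3 h in this assay, at which 1 of the 4 values shown sits.

On these data alone, it remains open whether a carboxylic acid or a tetrazole at this place would reach a similar number, and which atoms of the entering ring carry the rise.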